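The source may hold more compounds than are shown below. What is called first, only, known or untested is meant among the compounds shown, and "the series" means these compounds.

Of the compounds shown here, two built on a shared core have been measured in an in vitro functional assay on HEK285-7 cells for antagonist activity at prostaglandin D2 receptor 2 (Homo sapiens), read by BRET and beta-arrestin recruitment; on this read-out lower numbers stand for smaller maximal responses and higher numbers for larger maximal responses. Compound 1 `Cc1nc(-c2ccc(Cl)cc2)c(CC(=O)O)s1` gives 50% in this assay. Compound 2 `O=C(O)Cc1sc(C(c2ccc(F)cc2)c2ccc(F)cc2)nc1-c1ccnc(F)c1` gives 80% in this assay, the higher of the two numbers, and it stands a gap beyond the usual scatter above compound 1. Compound 3 `O=C(O)Cc1sc(C(c2ccc(F)cc2)c2ccc(F)cc2)nc1-c1ccnc(N2CCCC2)c1` has not yet been measured in this assay. It differs from compound 2 in one place: pyrrolidin-1-yl in place of fluoro on an aromatic carbon. Going by the values given here, no measured pair shows this particular change, so nothing is known about its effect from these data. Compound 2 already gives 80%, which leaves limited room upward. The expected step is no change at the digits printed from compound 2 to compound 3 (within the scatter), within the scatter or at most a small move in either direction. Compound 3 is therefore estimated at 80%, with a range from 65% to 95%.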

Compound 3, largest response reached (reported as efficacy), in percent of the reference or control that the assay uses: 80%
For compound 3 middle estimate and measured number coincide at the digits printed; the measured number falls inside the stated range.
By their numbers in this assay, from the lowest: compound 1; then compounds 2 and 3 (each within the scatter of the next).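

In this assay, replacing fluoro with pyrrolidin-1-yl gives no change at the digits printed from compound 2 to compound 3 (within the scatter), so the two compounds cannot be told apart on this read-out. This position, on an aromatic carbon next to the ring nitrogen, therefore accepts a ring of 5 heavy atoms in place of a single fluorine, and a hydrogen-bond acceptor is added, with the largest response staying within the scatter. No measurement available here offers an explanation for this result.

Going by these compounds, whether the same tolerance extends to other groups at this position stays open, for example a morpholin-4-yl ring, a primary amine or a carboxylic acid. The largest response also does not show how much of each compound is needed to reach it, so compound 2 and compound 3 may still differ in that respect.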